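The compounds below may be only part of what the source reports. "The series", "measured", "known", "first", "only" and "open" are said of these compounds alone.

Three compounds that share one core and differ only in the ring system attached to the chlorinated phenyl ring have been tested in an assay on C3H 10T1/2 cells for inhibition of Sonic hedgehog protein (Mus musculus), read by a luciferase reporter; a higher number here means a weaker inhibitor, a lower number a stronger inhibitor. Compound 1 `Cc1nc(C(F)(F)F)ccc1C(=O)Nc1ccc(Cl)c(-c2nc3c(n2C)CCCC3)c1` gives 150 nM. Compound 2 `Cc1nc(C(F)(F)F)ccc1C(=O)Nc1ccc(Cl)c(-n2cc3ccccc3n2)c1` gives 80 nM. Compound 3 `Cc1nc(C(F)(F)F)ccc1C(=O)Nc1ccc(Cl)c(-c2cn3ccsc3n2)c1` gives 200 nM, the highest of the three numbers: the step of a 1.3-fold higher number from compound 1 to compound 3 (0.12 log units; within the scatter) lies within the scatter, while the step of a 2.5-fold higher number from compound 2 to compound 3 (0.40 log units; beyond the scatter) is a modest but real difference, and the step of a 1.9-fold lower number from compound 1 to compound 2 (0.27 log units; within the scatter) is again within the scatter.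

Compound 4 `Cc1nc(C(F)(F)F)ccc1C(=O)Nc1ccc(Cl)c(-c2ccn(C)n2)c1` continues this series at the same position: a group of 6 heavy atoms (4 carbon, 2 nitrogen; one five-membered aromatic ring with 2 hetero atoms) in place of a group of 8 heavy atoms (5 carbon, 2 nitrogen, 1 sulfur; 2 five-membered aromatic rings with 2 hetero atoms each), on an aromatic carbon. All three measured steps concern exchanges of this very group, and none of them moved the number by more than a modest amount, so the spread among the measured compounds is narrow. The new group is a single five-membered aromatic ring rather than a fused pair, a somewhat larger departure than any of the measured exchanges, which argues for some added uncertainty but for no particular direction.

In this assay, compound 4 is therefore expected to give about 200 nM, with a likely range from 70 nM to 600 nM. The expected step of no change at the digits printed from compound 3 to compound 4 (within the scatter) is thus no change beyond the scatter.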

Compound 4, half-maximal inhibitory concentration: 550 nM
The estimate for compound 4 lay 2.8-fold (0.44 log units) below the measured number, within the range that was stated.
By their numbers in this assay, from the lowest: compounds 2, 1 and 3 (each within the scatter of the next, the first and the last beyond it); then compound 4.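

Replacing the fused pair of rings with the single 1-methyl-1H-pyrazol-3-yl ring gives the first clear loss at this position in this assay, seen in a 2.8-fold higher number from compound 3 to compound 4 (0.44 log units; beyond the scatter) and also in a 3.7-fold higher number from compound 1 to compound 4 (0.56 log units; beyond the scatter) and in a 6.9-fold higher number from compound 2 to compound 4 (0.84 log units; beyond the scatter) as the largest of the three. All three steps lie beyond the scatter, so compound 4 is the weakest inhibitor of the four, and this position on the aromatic carbon ortho to a chloro group proves less forgiving than the narrow spread among the earlier compounds suggested: each of those carries two rings in this group, and the one compound with a single ring stands apart, with no listed compound going against that pattern, though four compounds are a small base for it. Nothing available here accounts for this loss.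

For the compounds shown here, with only one single-ring group, it remains open whether the second ring itself matters or whether this particular pyrazole is the poor choice. A plain phenyl ring, a 1-methyl-1H-pyrazol-4-yl ring or a morpholine at the same place would help separate those two readings.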